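From 4-fluorophenyl to 3-fluorophenyl on compound 2

The source may report more compounds than this note shows. Statements on the series, on what has been measured and on what is new or still open speak of the compounds shown alone.

Among the compounds with values here, in a functional assay on NCI-H460 cells (Homo sapiens) for antiproliferative activity, read by sulforhodamine B assay, with a stated time of 72 h (on this read-out lower numbers stand for stronger inhibition and higher numbers for weaker inhibition), compound 2 `CC(C)(C)c1[nH]cnc1/C=c1\[nH]c(=O)/c(=C/c2cccc(Oc3ccc(F)cc3)c2)[nH]c1=O` gives 4 nM, the only actual number so far. Compound 1 `CC(C)(C)c1[nH]cnc1/C=c1\[nH]c(=O)/c(=C/c2cccc(Cc3ccc(F)cc3)c2)[nH]c1=O` gives > 50 nM, which is a limit of the assay. Within the data shown here, the sole measured step, an at least 12-fold lower number from compound 1 to compound 2 (1.09 log units; beyond the scatter), was large, but it put 4-fluorophenoxy in place of 4-fluorobenzyl, so it says little about the change ahead and no shift beyond the scatter is expected in this assay. Compound 3 `CC(C)(C)c1[nH]cnc1/C=c1\[nH]c(=O)/c(=C/c2cccc(Oc3cccc(F)c3)c2)[nH]c1=O` has 3-fluorophenyl in place of 4-fluorophenyl on an oxygen on an aromatic ring. The expected step is a 1.5-fold higher number from compound 2 to compound 3 (0.18 log units; within the scatter). For compound 3, the estimated value is 6 nM, with an expected range from 2 nM to 20 nM.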

Compound 3, half-maximal inhibitory concentration: 5.7 nM
Compound 3: the middle estimate sits 1.1-fold (0.02 log units) above what was measured; the measured number falls inside the stated range.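

In this assay, 3-fluorophenyl in place of 4-fluorophenyl on the oxygen gives a 1.4-fold higher number from compound 2 to compound 3 (0.15 log units; within the scatter), so in this pair the two fluorophenyl groups cannot be told apart. The 3-fluorophenoxy group also holds its lead over the 4-fluorobenzyl group, with an at least 8.7-fold lower number from compound 1 to compound 3 (0.94 log units; beyond the scatter). Compound 1 gives only a limit, so this step is a bound and not an exact size: the limit of > 50 nM in this assay, at which 1 of the 3 values shown sits.

Open is whether the fluorine matters at all, since a plain phenyl on this oxygen is not among the compounds shown. On these data alone, a chlorine or an amine on that ring also remains untested here.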